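The compounds below may be only part of what the source reports. "The series", "measured", "known", "first", "only" and "open" are said of these compounds alone.

Measured so far:
- compound 1 `Cc1nc(N2CCC(N3CCOC3=O)CC2)nc2ccc(NC(=O)/C=C/c3ccc(OC(F)(F)F)cc3)cc12`: 31 nM
- compound 2 `Cc1nc(N2CCC(N3CCCS3(=O)=O)CC2)nc2ccc(NC(=O)/C=C/c3ccc(OC(F)(F)F)cc3)cc12`: 16 nM

Both compounds were read in a functional assay on CHO-K1 cells for antagonist activity at melanin-concentrating hormone receptor 1 (Homo sapiens), read by inositol phosphate accumulation, with stated times of 10 min and 45 min; on this read-out lower numbers stand for stronger inhibition and higher numbers for weaker inhibition. Among the compounds with values here, compound 2 sits at 16 nM, with compound 1 at 31 nM; the one step between them, a 1.9-fold lower number from compound 1 to compound 2 (0.29 log units; within the scatter), is within the scatter, so the two values are not separated on this read-out.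

Compound 3 `Cc1nc(N2CCC(N3C(=O)CCC3=O)CC2)nc2ccc(NC(=O)/C=C/c3ccc(OC(F)(F)F)cc3)cc12` is the next member. Compared with compound 2 it carries a group of 7 heavy atoms (4 carbon, 1 nitrogen, 2 oxygen; one five-membered non-aromatic ring with 1 hetero atom) in place of a group of 7 heavy atoms (3 carbon, 1 nitrogen, 2 oxygen, 1 sulfur; one five-membered non-aromatic ring with 2 hetero atoms), on a saturated ring carbon. Within the data shown here, the only step in hand that bears on this position is a 1.9-fold lower number from compound 1 to compound 2 (0.29 log units; within the scatter), an exchange of one five-membered ring for another on the same saturated ring carbon that left the number within the scatter. On that basis the exchange in compound 3 is expected to give a step of about a 1.5-fold higher number from compound 2 to compound 3 (0.18 log units; within the scatter) in this assay, with no direction beyond the scatter.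

Compound 3 is therefore estimated at 24 nM, with a range from 8 nM to 75 nM.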

Compound 3, half-maximal inhibitory concentration: 35 nM
Compound 3: the middle estimate sits 1.5-fold (0.16 log units) below what was measured; the range from low to high includes it.
By their numbers in this assay, from the lowest: compounds 2, 1 and 3 (each within the scatter of the next, the first and the last beyond it).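

Within the data shown here, the 2,5-dioxopyrrolidin-1-yl group gives the first step at this saturated ring carbon that lies beyond the scatter in this assay: a 2.2-fold higher number from compound 2 to compound 3 (0.34 log units; beyond the scatter) is modest in size. With a 1.1-fold higher number from compound 1 to compound 3 (0.05 log units; within the scatter) this group is not separated from 2-oxo-1,3-oxazolidin-3-yl, so among these three compounds the only separated pair is compound 2 and compound 3, whose groups have equal counts of hydrogen-bond donors and acceptors. No measurement at hand accounts for this step.

From the compounds shown here alone, all three compounds carry a five-membered non-aromatic ring at this carbon, so it remains open how the number responds to a six-membered ring, an open-chain amide, a free amine or a carboxylic acid there. Going by these compounds, it is also open whether the modest step between compound 2 and compound 3 holds with a different group in place of the 4-trifluoromethoxyphenyl end of the molecule.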